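Swapping the Amide Tail on a Sulfonyl Piperidine Core

The source may report more compounds than this note shows. Statements on the series, on what has been measured and on what is new or still open speak of the compounds shown alone.

Three compounds share one core and differ only in the group on a saturated ring carbon. Compound 1 `Cc1cc(C)c(S(=O)(=O)N2CCC(N3CCC(CCO)CC3)CC2)c(C)c1` gives 19 nM in a functional assay on DLD-1 cells (Homo sapiens) for antiproliferative activity, read by CellTiter-Glo, with a stated time of 72 h; a lower number here means a stronger inhibitor, a higher number a weaker inhibitor. Compound 2 `Cc1ccc(C2CCN(S(=O)(=O)c3c(C)cc(C)cc3C)CC2)cc1` gives 2200 nM in this assay. Compound 3 `CCCC(=O)NC1CCN(S(=O)(=O)c2c(C)cc(C)cc2C)CC1` shows only > 5000 nM in this assay, which is a limit of the measurement and not a number (the limit of > 5000 nM in this assay, at which 1 of the 3 values shown sits). Compound 3 stands weakest of the three, since an at least 260-fold higher number from compound 1 to compound 3 (2.42 log units; beyond the scatter) and an at least 2.2-fold higher number from compound 2 to compound 3 (0.35 log units; beyond the scatter) both point to a higher number. Compound 4 `Cc1cc(C)c(S(=O)(=O)N2CCC(C(=O)N3CCC(C)CC3)CC2)c(C)c1` is not yet measured; the change is (4-methylpiperidin-1-yl)carbonyl in place of (propylcarbonyl)amino on a saturated ring carbon. The steps of a 120-fold higher number from compound 1 to compound 2 (2.06 log units; beyond the scatter) and an at least 260-fold higher number from compound 1 to compound 3 (2.42 log units; beyond the scatter) show that this position moves the number widely. For compound 4 a modest step downward is expected, an at least 1.6-fold lower number from compound 3 to compound 4 (0.22 log units; that floor lies within the scatter). The estimated value for compound 4 is 3000 nM, between 500 nM and 20000 nM.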

Compound 4, half-maximal inhibitory concentration: > 5000 nM
Compound 4: only a limit was reported; the forecaster's own chance of this, stated with the estimate: 40%; middle value at least 1.6-fold (0.22 log units) from the limit.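

In this assay compound 4 gives > 5000 nM, which is a limit of the assay and not a number. Compound 3 also has only a limit, so the step between these two cannot be read: the limit of > 5000 nM in this assay, at which 2 of the 4 values shown sit A piperidine ring at this position is clearly not enough on its own, with an at least 260-fold higher number from compound 1 to compound 4 (2.42 log units; beyond the scatter) and an at least 2.2-fold higher number from compound 2 to compound 4 (0.35 log units; beyond the scatter).

From the compounds shown here alone, it remains open whether the loss against compound 1 follows the added carbonyl or the methyl in place of the 2-hydroxyethyl chain. Going by these compounds, how a tail ending in an amine or a carboxylic acid would behave also remains open.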